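The source may hold more compounds than are shown below. What is called first, only, known or untested is meant among the compounds shown, and "the series" means these compounds.

Measured in a functional assay, read by spectrophotometry, tested at 100 uM; on this read-out lower numbers stand for stronger inhibition and higher numbers for weaker inhibition:
- compound 1 `O=C(/C=C/c1ccc(Cl)cc1)c1cccc(NC(=O)c2cc(-c3ccncc3)n[nH]2)c1`: 63900 nM
- compound 2 `CN(C)c1ccc(/C=C/C(=O)c2cccc(NC(=O)c3cc(-c4ccncc4)n[nH]3)c2)cc1`: 41900 nM
- compound 3 `O=C(/C=C/c1ccccc1Cl)c1cccc(NC(=O)c2cc(-c3ccncc3)n[nH]2)c1`: 27700 nM

Compound 3 and compound 2 share the low end of this small set, with a 1.5-fold lower number from compound 2 to compound 3 (0.18 log units; within the scatter). Compound 1 stands apart, with a 2.3-fold lower number from compound 1 to compound 3 (0.36 log units; beyond the scatter).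

The next compound to be measured is compound 4 `O=C(/C=C/c1ccc([N+](=O)[O-])cc1)c1cccc(NC(=O)c2cc(-c3ccncc3)n[nH]2)c1`, which differs from compound 3 in one place: 4-nitrophenyl in place of 2-chlorophenyl on a double-bonded chain carbon bound to a double-bonded chain carbon.

Among the compounds with values here, no measured compound carries 4-nitrophenyl, so the closest guides are compound 1, with 4-chlorophenyl, and compound 2, with 4-(dimethylamino)phenyl. Swapping one of these groups for the other gave only a 1.5-fold lower number from compound 1 to compound 2 (0.18 log units; within the scatter), so compound 4 may well land near that pair. Read in reverse, the two steps into compound 3 point towards a somewhat higher number for compound 4, although three compounds make a thin basis.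

The step expected in this assay is a 1.8-fold higher number from compound 3 to compound 4 (0.26 log units; within the scatter).

The estimate for compound 4 is 50000 nM, with an expected range of 22000 nM to 110000 nM.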

Compound 4, half-maximal inhibitory concentration: 52800 nM
Compound 4: middle estimate off by 1.1-fold (0.02 log units), on the low side, within the range that was stated.
By their numbers in this assay, from the lowest: compounds 3, 2, 4 and 1 (each within the scatter of the next, the first and the last beyond it).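

In this assay, nitro in place of chloro on an aromatic carbon gives a 1.2-fold lower number from compound 1 to compound 4 (0.08 log units; within the scatter), and nitro in place of dimethylamino gives a 1.3-fold higher number from compound 2 to compound 4 (0.10 log units; within the scatter), so compound 1, compound 2 and compound 4 cannot be told apart across these three groups. The change from 2-chlorophenyl to 4-nitrophenyl gives a 1.9-fold higher number from compound 3 to compound 4 (0.28 log units; within the scatter), which also leaves that pair unseparated, and the step between compound 1 and compound 3 remains the only one beyond the scatter. No measurement is available here that could explain this flat picture.

As far as these compounds go, it remains open whether a carboxylic acid or a primary amine on the same aromatic carbon would shift the number beyond the scatter. From the compounds shown here alone, it is also open whether 2-nitrophenyl would differ from 4-nitrophenyl, as 2-chlorophenyl does from 4-chlorophenyl.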